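The compounds below may be only part of what the source reports. "The series", "measured", "known", "first", "only" and "open" are said of these compounds alone.

Four compounds share one arrangement: a carbon with a double bond to nitrogen, flanked by two amide-type nitrogens, each carrying an aromatic acyl group, and bearing either a methylselanyl or a methylsulfanyl group. Compound 2 `C[Se]/C(=N\C(=O)c1ccno1)NC(=O)c1ccno1` and compound 1 `CS/C(=N\C(=O)c1ccno1)NC(=O)c1ccno1` carry the smaller aromatic acyl groups; compound 3 `C[Se]/C(=N\C(=O)c1cnc2ccccc2c1)NC(=O)c1cnc2ccccc2c1` and compound 4 `CS/C(=N\C(=O)c1cnc2ccccc2c1)NC(=O)c1cnc2ccccc2c1` carry the larger ones. The difference between the two cores is not broken down here.

In a functional assay on HepG2 cells (Homo sapiens) for cytotoxicity, read by MTT assay, with a stated time of 72 h (on this read-out higher numbers stand for weaker inhibition of growth and lower numbers for stronger inhibition of growth), compound 2 gives 510 nM. Compound 1 reaches only the limit of this assay, > 100000 nM, and that limit is the limit of > 100000 nM in this assay, at which 1 of the 3 values shown sits. The change from compound 2 to compound 1 is a group of 2 heavy atoms (1 carbon, 1 sulfur; no ring) in place of a group of 2 heavy atoms (1 carbon, 1 selenium; no ring), on a carbon with a double bond to nitrogen, and it made a step of an at least 190-fold higher number from compound 2 to compound 1 (2.29 log units; beyond the scatter).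

Compound 3 gives 4160 nM in this assay, the highest number among the measured compounds. Compound 4 differs from compound 3 by a group of 2 heavy atoms (1 carbon, 1 sulfur; no ring) in place of a group of 2 heavy atoms (1 carbon, 1 selenium; no ring), on a carbon with a double bond to nitrogen, which is the same change as from compound 2 to compound 1, at the same place.

Resting on the step from compound 2 to compound 1, an at least 190-fold higher number from compound 2 to compound 1 (2.29 log units; beyond the scatter), a step of similar size is expected from compound 3 to compound 4, a 96-fold higher number from compound 3 to compound 4 (1.98 log units; beyond the scatter), which would carry the number past the limit of this assay. Compound 4 is therefore estimated at 400000 nM, between 60000 nM and 3000000 nM, with a real chance that only a limit is reported.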

Compound 4, concentration for 50% growth inhibition: 57600 nM
Beside the measured number, compound 4's estimate is 6.9-fold (0.84 log units) above it; the measured number lies below the stated range.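

Replacing the selenium-bearing group with methylsulfanyl, on a carbon with a double bond to nitrogen, again raises the number in this assay on the second core, with a 14-fold higher number from compound 3 to compound 4 (1.14 log units; beyond the scatter). The direction of the change therefore carries over on these two cores, so the sulfur compound is the weaker growth inhibitor in both pairs, but the size of the change does not carry over: the same change on two cores in this assay, an at least 190-fold higher number (2.29 log units; beyond the scatter) from compound 2 to compound 1 and a 14-fold higher number (1.14 log units; beyond the scatter) from compound 3 to compound 4, at least 14-fold (1.15 log units) apart, beyond the scatter of two such steps

On these data alone, compound 1 gives > 100000 nM, which is a limit and not a number, so the true size of the first step stays unknown, and two cores show neither what sets the size of the step nor what the change would do on a third core.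

The compounds shown leave open whether the same change would keep its direction on a core whose aromatic acyl groups carry an amine or a carboxylic acid. They also leave open what happens when an ethyl group or a longer chain takes the place of the methyl on the selenium or the sulfur, and whether either pair would behave the same way in a cell line other than HepG2.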